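Phenyl for tert-butyl at the benzylic amine: compound 3

The source may hold more compounds than are shown below. What is called first, only, known or untested is meant among the compounds shown, and "the series" means these compounds.

Measured so far:
compound 1 `CC(C)(C)c1ccc(CNCCCNS(=O)(=O)c2cc(C(F)(F)F)cc(C(F)(F)F)c2)cc1` — 2700 nM
compound 2 `O=S(=O)(NCCCNCC1COc2ccccc2O1)c1cc(C(F)(F)F)cc(C(F)(F)F)c1` — 2900 nM

In a functional assay on ASPC1 cells (Homo sapiens) for inhibition, read by MTT assay, with a stated time of 72 h (a higher number here means a weaker inhibitor of growth, a lower number a stronger inhibitor of growth), compound 1 gives 2700 nM and compound 2 gives 2900 nM; the step of a 1.1-fold higher number from compound 1 to compound 2 (0.03 log units; within the scatter) does not separate them, so compound 1 stands with compound 2, not apart from it. Compound 3 `O=S(=O)(NCCCNCc1ccc(-c2ccccc2)cc1)c1cc(C(F)(F)F)cc(C(F)(F)F)c1` differs from compound 1 by phenyl in place of tert-butyl on an aromatic carbon. For the measured compounds named here, no measured step changes only this group; the one step available, which exchanged the whole 4-(tert-butyl)phenyl, stayed within the scatter. For compound 3 the expectation in this assay is therefore a step of a 1.1-fold lower number from compound 1 to compound 3 (0.03 log units; within the scatter), no more than the scatter. Compound 3 is estimated at 2500 nM, between 1000 nM and 7000 nM.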

Compound 3, concentration for 50% growth inhibition: 2500 nM
Beside the measured number, compound 3's estimate shows no gap at the digits printed, and the stated range covers the measured number.
By their numbers in this assay, from the lowest: compounds 3, 1 and 2 (each within the scatter of the next).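

Where the earlier step exchanged the whole 4-(tert-butyl)phenyl, this change touches only the group on the aromatic carbon, para to a large group. In this assay it gives a 1.1-fold lower number from compound 1 to compound 3 (0.03 log units; within the scatter), so a six-membered aromatic ring of carbon only and tert-butyl cannot be told apart at this position. No measured evidence bears on this result.

From the compounds shown here alone, whether an amine or a carboxylic acid at this aromatic carbon would move the number beyond the scatter stays open. So does the effect of a longer chain linking the two nitrogens.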